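Swapping the benzyl group: from compound 3 to compound 4

A few compounds are considered here, and "the series" means these few. Any claim that something is new, unique, unknown or untested is made for them only; others in the source may bear on it.

The measured compounds:
compound 1, `Cc1cccc(Cn2cc(COc3ccc4c(=O)ccoc4c3)nn2)c1`, gives 20300 nM in a functional assay on A549 cells (Homo sapiens) for cytotoxicity, read by MTT assay, with a stated time of 48 h; a higher number here means a weaker inhibitor, a lower number a stronger inhibitor.
compound 2, `N#Cc1ccc(Cn2cc(COc3ccc4c(=O)ccoc4c3)nn2)cc1`, reaches only the limit of > 100000 nM in this assay.
compound 3, `O=c1ccoc2cc(OCc3cn(Cc4ccccc4Cl)nn3)ccc12`, likewise reaches only the limit of > 100000 nM in this assay.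

Compound 3 therefore stands at a limit, not at a number, and the limit of > 100000 nM in this assay, at which 2 of the 3 values shown sit, marks where it sits. The step to compound 4, `N#Cc1cccc(Cn2cc(COc3ccc4c(=O)ccoc4c3)nn2)c1`, is 3-cyanophenyl in place of 2-chlorophenyl on a saturated chain carbon bound to an aromatic nitrogen. Among the compounds with values here, two measured steps bear on it. From the 3-methylphenyl of compound 1, both the 2-chlorophenyl and the 4-cyanophenyl variants moved to the limit: an at least 4.9-fold higher number from compound 1 to compound 3 (0.69 log units; beyond the scatter) and an at least 4.9-fold higher number from compound 1 to compound 2 (0.69 log units; beyond the scatter). Between the two limits themselves, a step that the two limits leave unreadable from compound 2 to compound 3. Compound 4 shares its nitrile with compound 2, which gives only a limit, and only the 3-substitution by name with compound 1. The expectation is therefore a weak inhibitor again, with a fair chance of a limit in this assay. Compound 4 is expected to give about 80000 nM, between 20000 nM and 300000 nM. That estimate means an expected step of an at least 1.2-fold lower number from compound 3 to compound 4 (0.09 log units; that floor lies within the scatter).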

Compound 4, half-maximal inhibitory concentration: 14300 nM
Compound 4: middle estimate off by 5.6-fold (0.75 log units), on the high side; the whole stated range lies above it.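

In this assay, the 3-cyanophenyl of compound 4 carries a nitrile and still gives a number rather than a limit, with an at least 6.9-fold lower number from compound 2 to compound 4 (0.84 log units; beyond the scatter). The change from the 2-chlorophenyl is a step of the same kind, an at least 6.9-fold lower number from compound 3 to compound 4 (0.84 log units; beyond the scatter). Cyano in place of methyl gives a 1.4-fold lower number from compound 1 to compound 4 (0.15 log units; within the scatter), so among these four compounds the 3-methylphenyl and 3-cyanophenyl groups give numbers, while the 4-cyanophenyl and 2-chlorophenyl groups, in compound 2 and compound 3, go against any reading that credits the nitrile or the chlorine alone.

The step between compound 2 and compound 3 cannot be read, both standing at a limit: the limit of > 100000 nM in this assay, at which 2 of the 4 values shown sit.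

Going by these compounds, whether a 3-aminophenyl or 3-carboxyphenyl group would also give a number, and what a longer chain in place of the benzyl carbon would do, stays open.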